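Trifluoromethyl for Propyl on the Aryl Ring

The compounds below may be only part of what the source reports. "The series", "measured", "known", "first", "only" and "open" are said of these compounds alone.

Of the compounds shown here, two have been measured in a functional assay on CHO cells for agonist activity at prostaglandin E2 receptor EP4 subtype (Rattus norvegicus), read by cAMP accumulation and immunoassay, with a stated time of 10 min; a higher number here means that more compound is needed for the effect, a lower number that less compound is needed. Compound 1 `O=C(O)CCCSCCN1C(=O)OC[C@@H]1/C=C/[C@@H](O)Cc1cccc(-c2ccccc2)c1` gives 450 nM. Compound 2 `CCCc1cccc(C[C@H](O)/C=C/[C@H]2CSC(=O)N2CCSCCCC(=O)O)c1` gives 6.1 nM, the lower of the two numbers; the gap between compound 1 and compound 2 lies well beyond the scatter, so compound 2 stands as the more potent of the pair. Compound 3 `O=C(O)CCCSCCN1C(=O)SC[C@@H]1/C=C/[C@@H](O)Cc1cccc(C(F)(F)F)c1` differs from compound 2 in a single place: trifluoromethyl in place of propyl on an aromatic carbon, meta to a large group on the six-membered aromatic ring of carbon only. Within the data shown here, no pair of measured compounds shows this change, so its effect has to be estimated. The group that enters is about as large as the one that leaves, and the rest of the molecule is kept, so the step is expected to be small, likely within the scatter or slightly upward: a 1.6-fold higher number from compound 2 to compound 3 (0.21 log units; within the scatter). In this assay compound 3 is estimated at 10 nM, with a range from 3 nM to 40 nM.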

Compound 3, half-maximal effective concentration: 4.3 nM
Estimate against measurement, compound 3: 2.3-fold (0.37 log units) above; the measured number falls inside the stated range.
By their numbers in this assay, from the lowest: compounds 3 and 2 (each within the scatter of the next); then compound 1.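

In this assay, among these compounds, trifluoromethyl in place of propyl on this aromatic carbon gives a 1.4-fold lower number from compound 2 to compound 3 (0.15 log units; within the scatter), so the two groups cannot be told apart here, and this is the first reading of a single change at this position. The 3-propylphenyl and 3-(trifluoromethyl)phenyl ends thus read alike, although the entering group carries fluorine where the leaving group holds only carbon. No measurement of any property of these groups accompanies the result, so nothing can be said about why they read alike.

The compounds shown leave open how an amine, a carboxylic acid or a longer chain such as butyl would read on this aromatic carbon. Also open, from the compounds shown here alone, is whether the same exchange would read alike on the core of compound 1.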